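The source may report more compounds than this note shows. Statements on the series, on what has been measured and on what is new or still open speak of the compounds shown alone.

Series notes. In a functional assay on OVCAR-3 cells (Homo sapiens) for antiproliferative activity, read by spectrophotometry, with a stated time of 2 days (a higher number here means a weaker inhibitor of growth, a lower number a stronger inhibitor of growth), compound 1 `CN(c1cccc2c1CN(c1nc(Nc3ccc(C(F)(F)F)cc3)ncc1C(F)(F)F)C2)S(C)(=O)=O` gives only a limit, > 30000 nM. Compound 2 `CN(c1cccc2c1CN(c1nc(Nc3ccc(Cl)c(C(F)(F)F)c3)ncc1C(F)(F)F)C2)S(C)(=O)=O` likewise gives only a limit in this assay, > 50000 nM. Compound 3 `COc1ccc(C(F)(F)F)cc1Nc1ncc(C(F)(F)F)c(N2Cc3cccc(N(C)S(C)(=O)=O)c3C2)n1` also sits at a limit in this assay, > 30000 nM. Two of the three values shown sit at the limit of > 30000 nM in this assay, at which 2 of the 3 values shown sit, and one at the limit of > 50000 nM in this assay, at which 1 of the 3 values shown sits, so the steps a step that the two limits leave unreadable from compound 1 to compound 2, a step that the two limits leave unreadable from compound 1 to compound 3 and a step that the two limits leave unreadable from compound 2 to compound 3 are all of unreadable size, and compound 3 cannot be placed against compound 1 or compound 2 beyond the fact that all three are limits.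

Compound 4 `CN(c1cccc2c1CN(c1nc(Nc3cccc(C(F)(F)F)c3)ncc1C(F)(F)F)C2)S(C)(=O)=O` differs from compound 3 by hydrogen in place of methoxy on an aromatic carbon. No measured step bears directly on this change, and none of the three shown steps has a readable size, so no direction can be drawn from them. The expected step that the limit leaves unreadable from compound 3 to compound 4 is therefore none beyond the scatter, with a limit the most likely outcome. In this assay compound 4 is estimated at 40000 nM, with a range from 12000 nM to 120000 nM.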

Compound 4, concentration for 50% growth inhibition: > 30000 nM
Compound 4: no number, only a limit (the forecaster's own chance of this, stated with the estimate: 80%); the middle value is on the limit's open side.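

In this assay compound 4 gives only a limit, > 30000 nM, so its steps from compound 1, compound 2 and compound 3 cannot be read. With all four values limits, it stays open whether any change on the phenyl group shown alters growth inhibition.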